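The compounds below may be only part of what the source reports. "The series", "measured", "known", "first", "only" and "open" are said of these compounds alone.

In an ADME assay (liver) for metabolic stability, with Liver microsome (Homo sapiens) as the target, using microsomes (a higher number here means faster removal of the compound, a lower number slower removal), compound 1 (`c1ccc(CNc2nnc(-c3nc4ccncc4s3)o2)cc1`) gives 23 mL.min-1.g-1 and compound 2 (`c1ccc(CNc2nnc(-c3c[nH]c4ncccc34)o2)cc1`) gives 31 mL.min-1.g-1, so compound 2 stands within the usual scatter of compound 1. Compound 3 (`c1ccc(CNc2nnc(-c3c[nH]c4ncccc34)o2)nc1`) differs from compound 2 by having pyridin-2-yl in place of phenyl on a saturated chain carbon bound to a nitrogen on an aromatic ring. Among the compounds with values here, no measured pair shows this swap, so the expectation rests on the structural change alone: a modest move towards a lower number in this assay and slower removal. The expected size is a 1.7-fold lower number from compound 2 to compound 3 (0.24 log units; within the scatter) by this estimate. Compound 3 is estimated at 18 mL.min-1.g-1, with an expected range from 8 mL.min-1.g-1 to 35 mL.min-1.g-1 in this measurement.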

Compound 3, intrinsic clearance in microsomes: < 14 mL.min-1.g-1
Compound 3: no number, only a limit (the forecaster's own chance of this, stated with the estimate: 3%); at least 1.2-fold (0.10 log units) between middle value and limit.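

In this assay, both earlier compounds carry phenyl at this place, so they say nothing about changing it. Pyridin-2-yl in its place on a saturated chain carbon bound to a nitrogen on an aromatic ring gives an at least 2.2-fold lower number from compound 2 to compound 3 (0.34 log units; beyond the scatter), which shows that this ring affects removal. Compound 3 has no number, only a limit of the assay: the limit of < 14 mL.min-1.g-1 in this assay, at which 1 of the 3 values shown sits.

On these data alone, how far its true value lies past that limit stays open, as does whether the same swap lowers the number on the core of compound 1. The compounds shown also do not tell whether pyridin-3-yl or pyridin-4-yl at this place would behave like pyridin-2-yl.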